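Cytotoxicity notes on the sulfonyl-bridged quinolinone series

The compounds below may be only part of what the source reports. "The series", "measured", "known", "first", "only" and "open" are said of these compounds alone.

Three members of this series have been tested in an ADME assay on 2209-23 cells (Homo sapiens) for cytotoxicity, read by WST assay; on this read-out lower numbers stand for higher toxicity in this test and higher numbers for lower toxicity in this test. Compound 1 `NC(=O)COc1ccc2c(c1)S(=O)(=O)C=C(c1c(O)c3cc(F)ccc3n(Cc3ccc(F)cc3)c1=O)N2` is the member with the amide-bearing ether on the bridged ring system. In this assay compound 1 returns only the assay limit, > 50000 nM. Compound 2 `CS(=O)(=O)Nc1ccc2c(c1)S(=O)(=O)C=C(c1c(O)c3ccc(Cl)cc3n(Cc3ccc(F)cc3)c1=O)N2` carries the methanesulfonamide on that ring together with a chloro substituent on the quinolinone part. In this assay compound 2 likewise reaches only the limit, > 50000 nM. Compound 3 `CS(=O)(=O)Nc1ccc2c(c1)S(=O)(=O)C=C(c1c(O)c3cc(F)ccc3n(Cc3ccc(F)c(F)c3)c1=O)N2` keeps the methanesulfonamide and pairs a fluoro quinolinone with a 3,4-difluorobenzyl group. In this assay compound 3 also gives no number but the limit, > 50000 nM.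

Going by the values given here, compound 3 therefore stands where every measured member stands, at the limit of > 50000 nM in this assay, at which 3 of the 3 values shown sit; no ordering among the three can be drawn, and no two of them differ in a single place, so no measured step exists.

Compound 4 `CS(=O)(=O)Nc1ccc2c(c1)S(=O)(=O)C=C(c1c(O)c3cc(F)ccc3n(Cc3ccncc3)c1=O)N2` is the next member, not yet tested. It differs from compound 3 by pyridin-4-yl in place of 3,4-difluorophenyl on a saturated chain carbon bound to an aromatic nitrogen. With every measured value sitting at the limit, the change from compound 3 to compound 4 is expected to give a number no higher from compound 3 to compound 4 (the limit leaves the size open), that is, no shift beyond the scatter. Compound 4 is expected to return 50000 nM in this assay, within 20000 nM to 100000 nM, most likely again as a limit rather than a number.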

Compound 4, half-maximal cytotoxic concentration: > 50000 nM
Compound 4 gave a limit, no number; the forecaster's own chance of this, stated with the estimate: 85%; the middle value lies on the limit itself.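

The step from compound 3 to compound 4, pyridin-4-yl in place of 3,4-difluorophenyl, cannot be read, since both compounds give only a limit: the limit of > 50000 nM in this assay, at which 4 of the 4 values shown sit.

The compounds shown leave open how far any of the four lies from that limit, and whether any change on the shared core yields a measurable number.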